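Dichlorophenyl sulfonamides on a shared core

This account rests on a few compounds, and the source may have more. Where it says the series, first, only, none or still open, it means among the compounds named here.

Compound 1 `CN(Cc1ccc(C2=NCCN2)cc1)C(=O)COCCN(C)S(=O)(=O)c1ccccc1C#N`: 6
Compound 2 `CN(Cc1ccc(C2=NCCN2)cc1)C(=O)COCCN(C)S(=O)(=O)c1c(Cl)cccc1Cl`: 7.2
Compound 3 `CN(Cc1ccc(C2=NCCN2)cc1)C(=O)COCCN(C)S(=O)(=O)c1ccccc1C(F)(F)F`: "not determined" (no result reported)

Three compounds share one core and differ only in the aryl group on the sulfonyl sulfur. For the measured compounds named here, in a functional assay for antagonist activity at B1 bradykinin receptor (Mus musculus), using Schild analysis, with a stated time of 30 min (a higher number here means a more potent compound, by a factor of ten per unit of this negative logarithm, a lower number a less potent compound), compound 1 gives 6, the lowest of the two numbers known; compound 2 gives 7.2, and for compound 3 the result is "not determined" (no result reported).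

Compound 4 `Cc1c(Cl)ccc(S(=O)(=O)N(C)CCOCC(=O)N(C)Cc2ccc(C3=NCCN3)cc2)c1Cl` has not yet been measured. It differs from compound 1 in this way:

2,4-dichloro-3-methylphenyl in place of 2-cyanophenyl on a sulfonyl sulfur

Going by the values given here, one measured step bears on it. Replacing the 2-cyanophenyl of compound 1 by 2,6-dichlorophenyl brought a number 1.20 log units higher from compound 1 to compound 2 (beyond the scatter). Compound 4 also carries two chlorines on the ring at the sulfonyl sulfur, together with a methyl, though placed as 2,4-dichloro-3-methylphenyl rather than 2,6-dichlorophenyl. Whether the shifted pattern matters cannot be read from the two numbers available, so the expectation leans on compound 2 while allowing a wide spread.

Among the compounds with values here, compound 4 is therefore expected to rise in this assay by about a number 1.00 log units higher from compound 1 to compound 4 (beyond the scatter), because compound 1 sits at 6 and the only dichloro analogue, compound 2, reached 7.2. The estimate for compound 4 is 7, within a range from 6.2 to 7.8.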

Compound 4, negative logarithm of the antagonist equilibrium constant: 7.5
Compound 4: middle estimate off by 0.50 log units, on the low side, and the stated range covers the measured number.
By their numbers in this assay, from the lowest: compound 1; then compounds 2 and 4 (each within the scatter of the next).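

In this assay, 2,4-dichloro-3-methylphenyl in place of 2-cyanophenyl on the sulfonyl sulfur gives a number 1.50 log units higher from compound 1 to compound 4 (beyond the scatter), so a second aryl group carrying two chlorines also stands clear of the 2-cyanophenyl compound. Exchanging 2,6-dichlorophenyl for 2,4-dichloro-3-methylphenyl gives a number 0.30 log units higher from compound 2 to compound 4 (within the scatter), so this different arrangement of the two chlorines, together with the added methyl, does not separate the two dichloro compounds in this measurement. No measurement offered alongside these numbers accounts for either step.

As far as these compounds go, whether one chlorine alone would match compound 2 and compound 4, and whether bromine, a methoxy group or an amine on the ring would hold the same level, remains open, as does the separate contribution of the methyl in compound 4. From the compounds shown here alone, compound 3, with its trifluoromethyl group, has no reported result, so every step involving it cannot be read, and the place of that group relative to the 2-cyanophenyl and dichloro compounds stays unknown.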